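Changing the Five-Membered Ring of Compound 3

This account rests on a few compounds, and the source may have more. Where it says the series, first, only, none or still open, it means among the compounds named here.

Measured compounds:
compound 1, `c1ccc(-c2ccncc2)c(OCC2=NCCN2)c1`, < 100000 nM
compound 2, `c1cnc(-c2ccccc2OCC2=NCCN2)nc1`, < 100000 nM
compound 3, `c1ccc(-c2nccs2)c(OCC2=NCCN2)c1`, 20 nM

In a functional assay for activation of Alpha-1B adrenergic receptor (Homo sapiens), read by calcium flux (a lower number here means that less compound is needed, a higher number that more compound is needed for the effect), compound 3 gives 20 nM, the only number among the three compounds shown. Compound 1 sits at a limit of the assay rather than at a number. Compound 2 likewise sits at a limit (the limit of < 100000 nM in this assay, at which 2 of the 3 values shown sit). The steps a step that the limit leaves unreadable from compound 1 to compound 3 and a step that the limit leaves unreadable from compound 2 to compound 3 therefore cannot be sized, and the step that the two limits leave unreadable from compound 1 to compound 2 cannot be sized either.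

Compound 4, `Cc1cnsc1-c1ccccc1OCC1=NCCN1`, differs from compound 3 in one place: 4-methyl-1,2-thiazol-5-yl in place of 1,3-thiazol-2-yl on an aromatic carbon. Going by the values given here, no measured step touches a change of this kind, since the two steps that lead to compound 3 are both unreadable. The two rings are of the same size and carry the same kinds of atoms, but the ring is attached differently and a methyl is added, so a wide range is expected. The step of a 7.5-fold higher number from compound 3 to compound 4 (0.88 log units; beyond the scatter) is the expected outcome. Compound 4 is estimated at 150 nM, between 10 nM and 3000 nM.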

Compound 4, half-maximal effective concentration: < 100000 nM
Compound 4: only a limit was reported; the forecaster's own chance of this, stated with the estimate: 10%; the middle value does not contradict the limit.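

Compound 4 gives a limit of the assay and not a number, so no step linking it to compound 1, compound 2 or compound 3 can be read: the limit of < 100000 nM in this assay, at which 3 of the 4 values shown sit.

The compounds shown leave open how far compound 3 really stands from the other three in this assay.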